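Swapping 4-methoxyphenyl for 2,3,5-trichlorophenyl in the bromo compound

The compounds below may be only part of what the source reports. "The series", "measured", "known", "first", "only" and "open" are said of these compounds alone.

For the measured compounds named here, in a functional assay on DU-145 cells (Homo sapiens) for inhibition, read by trypan blue exclusion, with a stated time of 96 h (a lower number here means a stronger inhibitor of growth, a higher number a weaker inhibitor of growth), compound 1 (`COc1ccc(/C=C(/SCc2ccc(Cl)cc2)C(=O)c2ccc(Br)cc2)cc1`) gives 10000 nM and stands level with the only other measured member of the series. That member is compound 2 (`COc1ccc(/C=C(/SCc2ccc(Cl)cc2)C(=O)c2ccc(C(=O)O)cc2)cc1`) at 10000 nM in the same read-out. Compound 3 (`O=C(/C(=C\c1cc(Cl)cc(Cl)c1Cl)SCc1ccc(Cl)cc1)c1ccc(Br)cc1`) keeps the bromo group and the shared core but differs from compound 1 on a double-bonded chain carbon bound to a double-bonded chain carbon (2,3,5-trichlorophenyl in place of 4-methoxyphenyl on a double-bonded chain carbon bound to a double-bonded chain carbon) where 2,3,5-trichlorophenyl takes the place of 4-methoxyphenyl.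

One measured step exists, carboxy in place of bromo on an aromatic carbon, and it shows no change at the digits printed from compound 1 to compound 2 (within the scatter) in this assay at a different place from the present change. Going by the values given here, no measured step touches the 4-methoxyphenyl, so the data give no size for this swap and the estimate stays loose. Only a small move is expected, with a slight lean toward stronger inhibition of growth and nothing firmly expected beyond the scatter. The expected step is a 1.7-fold lower number from compound 1 to compound 3 (0.22 log units; within the scatter) in this estimate. For compound 3 the estimated value is 6000 nM with an expected range from 1500 nM to 15000 nM in this work.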

Compound 3, concentration for 50% growth inhibition: 1000 nM
Compound 3: middle estimate off by 6.0-fold (0.78 log units), on the high side; the whole stated range lies above it.
By their numbers in this assay, from the lowest: compound 3; then compounds 1 and 2 (each within the scatter of the next).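

In this assay, for the compounds shown here, the exchange of 4-methoxyphenyl for 2,3,5-trichlorophenyl on a double-bonded chain carbon bound to a double-bonded chain carbon gives a 10-fold lower number from compound 1 to compound 3 (1.00 log units; beyond the scatter), the only step so far that lies beyond the scatter. The earlier pair showed only no change at the digits printed from compound 1 to compound 2 (within the scatter), at a different place, so this position is the first shown to respond in this read-out, here with the bromo group held constant. The information at hand offers no measured basis for explaining the step.

The swap removes the methoxy group and brings in the three chlorines in one move, so the compounds shown do not tell how much of the step goes with each; a plain phenyl or a 4-chlorophenyl at this position would divide it. Going by these compounds, it also remains open whether 2,3,5-trichlorophenyl gives a similar step with the carboxy group of compound 2 in place of the bromo group, and whether an amine on this ring would keep the lower number of compound 3.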